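The source may report more compounds than this note shows. Statements on the series, on what has been measured and on what is new or still open speak of the compounds shown alone.

Measured compounds:
compound 1 `Cc1ccc(S(=O)(=O)c2cnc3cc(F)ccc3c2N2CCC(C)CC2)cc1C`, 90%
compound 2 `Cc1ccc(S(=O)(=O)c2cnc3cc(Cl)ccc3c2N2CCC(C)CC2)cc1F`, 85%
compound 3 `CC1CCN(c2c(S(=O)(=O)c3ccc(Cl)c(Cl)c3)cnc3cc(F)ccc23)CC1`, 94%

All three compounds were tested in an assay on isolated protein for displacement of a labelled ligand from metabotropic glutamate receptor 5 (Homo sapiens), with a stated time of 60 min, tested at 1 uM; on this read-out lower numbers stand for less inhibition and higher numbers for more inhibition at the one concentration tested (going by the name of the read-out). Compound 2 gives the lowest of the three numbers, 85%; its nearest neighbour is compound 1 with 90%, and the furthest is compound 3 with 94%, both gaps lying within the scatter, so no order among the three can be claimed.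

Compound 4 `COc1ccc(S(=O)(=O)c2cnc3cc(Cl)ccc3c2N2CCC(C)CC2)cc1Cl` has not been measured. It differs from compound 2 as follows: 3-chloro-4-methoxyphenyl in place of 3-fluoro-4-methylphenyl on a sulfonyl sulfur. Among the measured compounds shown here, the only measured step at the same place is the one from compound 1 to compound 3, where a 3,4-dichlorophenyl replaced a 3,4-dimethylphenyl on the sulfonyl sulfur: a number 4 percentage points higher from compound 1 to compound 3 (within the scatter). That change on the sulfonyl aryl left the read-out essentially unchanged, and the step from compound 2 to compound 4, a different substituent pair on the same aryl, is therefore expected to stay within the scatter as well, a number 1 percentage points higher from compound 2 to compound 4 (within the scatter).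

Compound 4 is accordingly estimated to give 86% in this assay, with a range from 70% to 96%.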

Compound 4, a percentage reported as inhibition, at one concentration (the size of the read-out at that concentration, not a potency): 93%
Compound 4: middle estimate off by 7 percentage points, on the low side; measured number inside the range.
By their numbers in this assay, from the lowest: compounds 2, 1, 4 and 3 (each within the scatter of the next).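

A second change on a sulfonyl sulfur can now be read in this assay, this time on the core of compound 2 rather than that of compound 1: a number 8 percentage points higher from compound 2 to compound 4 (within the scatter). The 3-chloro-4-methoxyphenyl group is counted with a hydrogen-bond acceptor, whereas the 3-fluoro-4-methylphenyl group it replaces has none, yet this difference leaves the number within the scatter. Nothing in the data shown explains this result.

All the numbers shown are high and each lies within the scatter of the next, so they do not tell how far this aryl group can be changed before the read-out falls, and a single concentration gives no potency. From the compounds shown here alone, whether a carboxylic acid or an amine on this aryl group, or a longer chain in its place, would keep the number this high remains open.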